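Working notes: benzyloxy for benzylamino, cytotoxicity series

The source may report more compounds than this note shows. Statements on the series, on what has been measured and on what is new or still open speak of the compounds shown alone.

Measured so far in an ADME assay on HEL cells (Homo sapiens) for cytotoxicity, with a stated time of 3 days; on this read-out higher numbers stand for lower toxicity in this test and lower numbers for higher toxicity in this test:
compound 1, `CCC1(Cc2ccccc2)OS(=O)(=O)C=C1OS(=O)(=O)c1ccc(C)cc1`: 400000 nM
compound 2, `CCC1(Cc2ccccc2)OS(=O)(=O)C=C1NCc1ccccc1`: >= 80000 nM

The value given for compound 2 is a limit of this assay, not a number. Compound 2 therefore stands at the limit of >= 80000 nM in this assay, at which 1 of the 2 values shown sits, and its true cytotoxic concentration can only be said to lie at or beyond that point. Among the compounds with values here, compound 1 is the only compound of the pair with a definite number, and that number points to low toxicity on this read-out. Within the data shown here, no step between two measured compounds that differ in one place is available.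

Compound 3, `CCC1(Cc2ccccc2)OS(=O)(=O)C=C1OCc1ccccc1`, differs from compound 2 by benzyloxy in place of benzylamino on a double-bonded ring carbon. Both measured compounds show low toxicity here, and nothing in the data points the other way. The step that the limit leaves unreadable from compound 2 to compound 3 is expected to stay within the usual scatter, with no clear direction. Compound 3 is estimated at 200000 nM, with a range from 50000 nM to 600000 nM.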

Compound 3, minimum cytotoxic concentration: >= 50000 nM
Compound 3: only a limit was reported (the forecaster's own chance of this, stated with the estimate: 40%); the middle value does not contradict the limit.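

Within the data shown here, compound 2 and compound 3 are both reported only as limits, and no step between them can be read. The compounds shown leave open where either true minimum cytotoxic concentration lies, and whether benzyloxy in place of benzylamino on a double-bonded ring carbon shifts it.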